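One Amide Substituent Swap Beneath the Assay Ceiling

The source may hold more compounds than are shown below. What is called first, only, known or untested is meant among the compounds shown, and "the series" means these compounds.

Compound 1 (`CCCCCN1C(=O)C/C(=C\c2cccc(C(=O)Nc3ccc(C)cc3)c2)C1=O`) was tested in an ADME assay on SW480 cells (Homo sapiens) for cytotoxicity, read by MTT assay, with a stated time of 72 h; on this read-out higher numbers stand for weaker inhibition and lower numbers for stronger inhibition. In this assay compound 1 gives only a limit, > 100000 nM. Compound 2 (`COc1ccc(NC(=O)c2cccc(/C=C3\CC(=O)N(c4ccccc4)C3=O)c2)c(C)c1`) is a second member of the same series. In this assay compound 2 likewise gives only a limit, > 100000 nM. Both results sit at the limit of > 100000 nM in this assay, at which 2 of the 2 values shown sit, so neither compound shows measurable cytotoxicity here, and compound 1 cannot be placed above or below compound 2.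

Compound 3 (`CCCCCN1C(=O)C/C(=C\c2cccc(C(=O)Nc3cccc(CC)c3)c2)C1=O`) has not yet been measured. It differs from compound 1 in one place: 3-ethylphenyl in place of 4-methylphenyl on an amide-type nitrogen. Going by the values given here, no measured pair in this set shows what such a change does, so the size of this step has no precedent. The step expected here, a step that the limit leaves unreadable from compound 1 to compound 3, is expected to amount to nothing beyond the usual scatter. Compound 3 is expected at 150000 nM, with a range from 80000 nM to 400000 nM, and most likely will be reported again only as a limit.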

Compound 3, half-maximal inhibitory concentration: 83300 nM
Compound 3: the middle estimate sits 1.8-fold (0.26 log units) above what was measured; measured number inside the range.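

Compound 3 is the first compound in this set to give a true number rather than a limit, while the other two stay at the ceiling: the limit of > 100000 nM in this assay, at which 2 of the 3 values shown sit.

In this assay, placing 3-ethylphenyl instead of 4-methylphenyl on the amide-type nitrogen gives an at least 1.2-fold lower number from compound 1 to compound 3 (0.07 log units; that floor lies within the scatter). The start of this step is only a limit, so the true size of the change cannot be read, and what can be read is a floor and no more.

The change alters both the chain and its place on the phenyl ring, and the compounds shown do not separate these two. Also open, on these data alone, is what a longer chain such as propyl, or a carboxylic acid, on that phenyl ring would give in this assay.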